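Cytotoxicity notes on the step to compound 3

The compounds below may be only part of what the source reports. "The series", "measured", "known", "first", "only" and "open" are said of these compounds alone.

- compound 1 `CCC(c1ccccc1)c1cc(O)nc(SC(C)C)n1` gives > 200000 nM as a limit
- compound 2 `CCC(C)Sc1nc(O)cc(C(C)c2ccccc2)n1` gives 200000 nM as a number

The reading for compound 1 is the limit of > 200000 nM in this assay, at which 1 of the 2 values shown sits, and stands only as a limit. Within the data shown here, compound 2 at 200000 nM holds the only number so far in a functional assay on MT4 cells (Homo sapiens) for cytotoxicity (a higher number here means that more compound is tolerated, a lower number that less compound is tolerated), and anchors the series.

Going to compound 3 `CCC(C)Sc1nc(O)cc(C(CC)c2ccccc2)n1` puts methyl in place of hydrogen on a saturated chain carbon, two bonds along the chain from two aromatic carbons, counted as methyl in place of hydrogen on a saturated chain carbon, two bonds along the chain from two aromatic carbons and read as methyl to ethyl.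

Among the measured compounds shown here, no measured step covers such a change, so no shift beyond the scatter is expected in this assay in either direction. For the measured compounds named here, the expected 1.2-fold lower number from compound 2 to compound 3 (0.07 log units; within the scatter) stays within the scatter, resting on compound 2 at 200000 nM as the sole number. A reading reported only as a limit is also possible. For compound 3 the estimated value is 170000 nM with an expected range from 70000 nM to 300000 nM for this measurement.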

Compound 3, half-maximal cytotoxic concentration: > 200000 nM
Compound 3 ended at the assay's limit; the forecaster's own chance of this, stated with the estimate: 50%; middle value at least 1.1-fold (0.07 log units) from the limit.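

Methyl to ethyl, on a saturated chain carbon, two bonds along the chain from two aromatic carbons, now has a measured step in this assay, the first at this position, and it reads as a number no lower from compound 2 to compound 3 (the limit leaves the size open). Compound 3 gives > 200000 nM, which is a limit and not a number. The added methyl therefore brings no lower tolerated concentration in this pair, while the step involving compound 1 cannot be read, since both of its ends are limits.

The size of the step stays open, and most of the series now offers no number to compare against: the limit of > 200000 nM in this assay, at which 2 of the 3 values shown sit.

From the compounds shown here alone, whether a longer chain such as propyl, or an amine, on this carbon would give a readable number in this assay also remains open.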